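The compounds below may be only part of what the source reports. "The series", "measured", "known", "first", "only" and "open" are said of these compounds alone.

Series at a glance, in a functional assay (Sus scrofa) with sulfonylurea receptors; K-ATP channels (Homo sapiens) as the target; on this read-out higher numbers stand for larger maximal responses and lower numbers for smaller maximal responses:
compound 1 `CC(C)=CC(=O)Nc1c(C(O)(C(F)(F)F)C(F)(F)F)ccc2ccccc12` gives 96%
compound 2 `O=C(Nc1c(C(O)(C(F)(F)F)C(F)(F)F)ccc2ccccc12)c1cccc(Cl)c1` gives 84%
compound 3 `O=C(Nc1c(C(O)(C(F)(F)F)C(F)(F)F)ccc2ccccc12)c1ccco1` gives 96%

Compound 1 stands level with compound 3 at the digits shown, the two together at the top of the three numbers; compound 2 sits lower, and the step of a number 12 percentage points lower from compound 1 to compound 2 (beyond the scatter) lies beyond the scatter. The shared core of compound 1 is kept throughout; only the group on the carbonyl carbon varies.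

Compound 4 `O=C(Nc1c(C(O)(C(F)(F)F)C(F)(F)F)ccc2ccccc12)c1cccnc1` has not been measured. Its difference from compound 1: pyridin-3-yl in place of 2-methylprop-1-en-1-yl on a carbonyl carbon. Within the data shown here, two measured steps bear on this exchange. Replacing the same group by furan-2-yl gave no change at the digits printed from compound 1 to compound 3 (within the scatter), while replacing it by 3-chlorophenyl gave a number 12 percentage points lower from compound 1 to compound 2 (beyond the scatter). The entering group is a six-membered aromatic ring with one hetero atom, so it shares features with each comparator. A small step down, or none beyond the scatter, is therefore expected: a number 6 percentage points lower from compound 1 to compound 4 (within the scatter). For compound 4 the expected value in this assay is 90%, with a range from 78% to 100%.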

Compound 4, largest response reached (reported as efficacy), in percent of the reference or control that the assay uses: 97%
Compound 4: middle estimate off by 7 percentage points, on the low side; the range from low to high includes it.
By their numbers in this assay, from the lowest: compound 2; then compounds 1, 3 and 4 (each within the scatter of the next).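

In this assay, the exchange on the carbonyl carbon to pyridin-3-yl leaves the response unmoved against both the open-chain 2-methylprop-1-en-1-yl group (a number 1 percentage points higher from compound 1 to compound 4 (within the scatter)) and the five-membered furan-2-yl ring (a number 1 percentage points higher from compound 3 to compound 4 (within the scatter)), so this position tolerates a six-membered aromatic ring with a ring nitrogen without loss. Ring size alone therefore does not account for the lower number of compound 2, since two six-membered aromatic rings stand apart here (a number 13 percentage points higher from compound 2 to compound 4 (beyond the scatter)). No measurement at hand explains why these two rings differ.

Going by these compounds, whether the lower number goes with the chlorine itself or with the 3-chlorophenyl group as a whole stays open, and a plain phenyl ring would bear on that. Also open, on these data alone, is what an amine, a carboxylic acid or a longer alkyl chain would give on this carbonyl carbon.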